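The source may report more compounds than this note shows. Statements on the series, on what has been measured and on what is new or still open speak of the compounds shown alone.

Working notes on the series in a functional assay on the whole organism with Rattus norvegicus as the target; on this read-out lower numbers stand for an effect already at smaller amounts and higher numbers for an effect only at larger amounts of compound. Compound 3 `CCC(C)(C)c1ccc2nc(N)sc2c1` stands at > 10 mg/kg, which is a limit and not a number. Compound 1 `Nc1nc2ccc(I)cc2s1` gives > 10 mg/kg, also a limit. Compound 1 and compound 3 thus share (the limit of > 10 mg/kg in this assay, at which 2 of the 3 values shown sit). Going by the values given here, compound 2 `C[Si](C)(C)c1ccc2nc(N)sc2c1` gives 5 mg/kg, the only true number so far.

The change under review leads to compound 4 `Nc1nc2ccc(SC(F)(F)F)cc2s1`: (trifluoromethyl)sulfanyl in place of 1,1-dimethylpropyl on an aromatic carbon, with (trifluoromethyl)sulfanyl in place of 1,1-dimethylpropyl on an aromatic carbon.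

Among the compounds with values here, three measured steps bear on it, all changes of the group on an aromatic carbon. The first is an at least 2.0-fold lower number from compound 1 to compound 2 (0.30 log units; that floor lies within the scatter). The second is an at least 2.0-fold higher number from compound 2 to compound 3 (0.30 log units; that floor lies within the scatter). The third is a step that the two limits leave unreadable from compound 1 to compound 3. None of them gives a size beyond the scatter, so the expectation remains loose.

With compound 2 at 5 mg/kg as the only numerical anchor, a modest move to a lower number is expected in this assay. For compound 4 a result at the limit also remains possible. The estimated step is an at least 2.0-fold lower number from compound 3 to compound 4 (0.30 log units; that floor lies within the scatter). The estimate for compound 4 is 5 mg/kg, with an expected range from 1.5 mg/kg to 15 mg/kg.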

Compound 4, dose for half-maximal effect: 8 mg/kg
The estimate for compound 4 lay 1.6-fold (0.20 log units) below the measured number, within the range that was stated.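

In this assay, going by these compounds alone, this position now carries a second group that gives a true number, and the comparison with the only earlier number is a 1.6-fold higher number from compound 2 to compound 4 (0.20 log units; within the scatter), so (trifluoromethyl)sulfanyl and the group of compound 2 cannot be told apart here. The other two readable comparisons are an at least 1.2-fold lower number from compound 3 to compound 4 (0.09 log units; that floor lies within the scatter) and an at least 1.2-fold lower number from compound 1 to compound 4 (0.09 log units; that floor lies within the scatter), so replacing 1,1-dimethylpropyl or iodo shows no size beyond the scatter. Compound 1 and compound 3 each remain a limit and not a number: the limit of > 10 mg/kg in this assay, at which 2 of the 4 values shown sit.

As far as these compounds go, the true size of the steps from compound 1 and compound 3 stays open. Also open, from the compounds shown here alone, is how an amine, a carboxylic acid or a longer chain on this aromatic carbon would read in this assay.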